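Removing a Methoxy Group: Cytotoxicity at the Limit

This account rests on a few compounds, and the source may have more. Where it says the series, first, only, none or still open, it means among the compounds named here.

Compound 1, `O=C(c1ccncc1)N1N=C(c2cc3ccccc3o2)CC1c1ccccc1[N+](=O)[O-]`: in an ADME assay on Vero cells (Chlorocebus sabaeus) for cytotoxicity, read by MTT assay, with a stated time of 72 h (a lower number here means a stronger inhibitor, a higher number a weaker inhibitor), compound 1 gives > 245000 nM, a limit of the assay rather than a number.
Compound 2, `COc1ccc(C2CC(c3cc4ccccc4o3)=NN2C(=O)c2ccncc2)cc1`: in this assay compound 2 gives > 200000 nM, again a limit rather than a number.

Compound 2 therefore stands only at a limit in this assay, with no number of its own, and compound 1 sits at a limit as well. The step that the two limits leave unreadable from compound 1 to compound 2 is accordingly unreadable; the two limits the limit of > 200000 nM in this assay, at which 1 of the 2 values shown sits, and the limit of > 245000 nM in this assay, at which 1 of the 2 values shown sits, leave both its size and its direction open. Compound 3, `O=C(c1ccncc1)N1N=C(c2cc3ccccc3o2)CC1c1ccccc1`, differs from compound 2 by hydrogen in place of methoxy on an aromatic carbon. Going by the values given here, only one measured step exists here, and it is the unreadable one, so no measured change gives a size to set against this one. With both measured compounds at the limit, the step that the limit leaves unreadable from compound 2 to compound 3 is expected to be none beyond the scatter, and compound 3 is expected to remain at or near the same limit. The estimate for compound 3 in this assay is 250000 nM, within a range from 120000 nM to 500000 nM, with a strong chance that the assay again reports only a limit.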

Compound 3, half-maximal inhibitory concentration: > 209000 nM
Compound 3 ended at the assay's limit; the forecaster's own chance of this, stated with the estimate: 85%; the middle value does not contradict the limit.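

In this assay compound 3 gives > 209000 nM, a limit of the assay and not a number. Going by these compounds alone, compound 1, compound 2 and compound 3 thus all stand at limits, and no step among them can be read. The compounds shown leave open where any of the three would fall as a number, and whether 2-nitrophenyl, 4-methoxyphenyl and phenyl differ at all.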